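Removing one methoxy group from compound 1

The source may report more compounds than this note shows. Statements on the series, on what has been measured and on what is new or still open speak of the compounds shown alone.

In a functional assay on A549 cells (Homo sapiens) for antiproliferative activity, read by MTT assay, with a stated time of 48 h (on this read-out higher numbers stand for weaker inhibition and lower numbers for stronger inhibition), compound 1 (`COc1cc(/C=N/c2c(C#N)ncn2-c2ccc(F)cc2)cc(OC)c1OC`) gives 9880 nM. Two compounds sharing its core have also been measured: compound 2 (`COc1ccc(OC)c(/C=N/c2c(C#N)ncn2-c2ccc(F)cc2)c1`) gives 9280 nM, and compound 3 (`N#Cc1ncn(-c2ccc(F)cc2)c1/N=C/c1cc([N+](=O)[O-])ccc1O`) gives 17200 nM. Compound 1 stands within the usual scatter of both, so these three numbers support no ranking. Within the data shown here, none of the measured pairs differs in only one place, which leaves no direct step to draw on.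

Compound 4 (`COc1ccc(/C=N/c2c(C#N)ncn2-c2ccc(F)cc2)cc1OC`) has not yet been measured. It differs from compound 1 in a single place, with hydrogen in place of methoxy on an aromatic carbon, ortho to a methoxy group, meta to a large group and meta to a methoxy group (hydrogen in place of methoxy on an aromatic carbon).

Compound 2 at 9280 nM and compound 3 at 17200 nM both stay within the scatter of compound 1, despite their different substitution. On that limited basis, no step beyond the scatter is expected in this assay, and neither direction is favoured. The estimated change, a 1.0-fold higher number from compound 1 to compound 4 (0.01 log units; within the scatter), is accordingly small. For compound 4 the expected value is 10000 nM, with an estimated range from 4500 nM to 22000 nM.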

Compound 4, half-maximal inhibitory concentration: 2960 nM
Beside the measured number, compound 4's estimate is 3.4-fold (0.53 log units) above it, and the stated range ends above it.
By their numbers in this assay, from the lowest: compound 4; then compounds 2, 1 and 3 (each within the scatter of the next).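

In this assay, among these compounds, hydrogen in place of methoxy on this aromatic carbon, ortho to a methoxy group, meta to a large group and meta to a methoxy group, gives a 3.3-fold lower number from compound 1 to compound 4 (0.52 log units; beyond the scatter), a modest step beyond the scatter and the first comparison in this set that differs in only one place. The earlier compounds shown here could not show whether this position matters, since none of them formed such a pair; this step shows that the number responds to this single change, and that the methoxy group here is not required for the inhibition seen with compound 1, as its loss goes with stronger inhibition. Nothing measured alongside these numbers bears on why the step occurs.

The compounds shown leave open whether another group on this aromatic carbon, such as a hydroxy group, a fluorine atom or an amine, would keep, extend or reverse the step. They also leave open whether taking away either of the two methoxy groups that remain in compound 4 would move the number in the same direction.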